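Sulfonyl aryl swap on a low-inhibition factor X sulfonamide

This account rests on a few compounds, and the source may have more. Where it says the series, first, only, none or still open, it means among the compounds named here.

Measured compounds:
compound 1 `O=C1[C@@H](NS(=O)(=O)c2ccc(-c3ccon3)s2)CCN1Cc1cc2c[nH]ccc-2n1` — 17%
compound 2 `O=C1[C@@H](NS(=O)(=O)c2ccc(-c3ccon3)s2)CCN1Cc1cc2cc[nH]cc-2n1` — 49%

In an assay on isolated protein for inhibition of coagulation factor X (Oryctolagus cuniculus), tested at 1 uM (on this read-out higher numbers stand for more inhibition at the one concentration tested (going by the name of the read-out) and lower numbers for less inhibition), compound 1 gives 17%, the lowest of the two numbers; the step of a number 32 percentage points higher from compound 1 to compound 2 (beyond the scatter) sits on a saturated chain carbon bound to an amide-type nitrogen in a ring. Compound 3 `O=C1[C@@H](NS(=O)(=O)c2cc3ncccc3s2)CCN1Cc1cc2c[nH]ccc-2n1` differs from compound 1 elsewhere: a group of 9 heavy atoms (7 carbon, 1 nitrogen, 1 sulfur; one five-membered aromatic ring with 1 hetero atom, one six-membered aromatic ring with 1 hetero atom) in place of a group of 10 heavy atoms (7 carbon, 1 nitrogen, 1 oxygen, 1 sulfur; one five-membered aromatic ring with 1 hetero atom, one five-membered aromatic ring with 2 hetero atoms), on a sulfonyl sulfur. Among the compounds with values here, no measured step touches the sulfonyl sulfur, so the only step known gives no guide here. Compound 3 is therefore expected near the level of compound 1, at an estimated 25% (range 5% to 55%), a step of a number 8 percentage points higher from compound 1 to compound 3 (within the scatter) that may well fall within the scatter.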

Compound 3, a percentage reported as inhibition, at one concentration (the size of the read-out at that concentration, not a potency): 61%
Estimate against measurement, compound 3: 36 percentage points below; the whole stated range lies below it.
By their numbers in this assay, from the lowest: compound 1; then compound 2; then compound 3.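

In this assay, the sulfonyl sulfur turns out to be a place that responds strongly: with the step of a number 44 percentage points higher from compound 1 to compound 3 (beyond the scatter), 5-(1,2-oxazol-3-yl)thiophen-2-yl gives way to a group with a six-membered aromatic ring with 1 hetero atom. So changes at this place, as well as the earlier change on the saturated chain carbon, can move the number beyond the scatter. Nothing available accounts for this step. The group of compound 3 is shown only on the core of compound 1, so its effect on the core of compound 2 remains open. Also open, from the compounds shown here alone, is how a plain phenyl or a chlorothiophene would behave on the sulfonyl sulfur.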